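From chloro to isopropyl: the next step in HDAC6 inhibition

A few compounds are considered here, and "the series" means these few. Any claim that something is new, unique, unknown or untested is made for them only; others in the source may bear on it.

Compound 1, `NS(=O)(=O)NCCCC[C@H](NC(=O)OCc1ccccc1)C(=O)Nc1nccs1`, gives 4100 nM in an assay for inhibition of protein deacetylase HDAC6 (Homo sapiens); on this read-out higher numbers stand for weaker inhibition and lower numbers for stronger inhibition.
Compound 2, `CCOC(=O)c1csc(NC(=O)[C@H](CCCCNS(N)(=O)=O)NC(=O)OCc2ccccc2)n1`, gives 580 nM in this assay.
Compound 3, `NS(=O)(=O)NCCCC[C@H](NC(=O)OCc1ccccc1)C(=O)Nc1nc(-c2ccc(Cl)cc2)cs1`, gives 250 nM in this assay.

Compound 3 stands lowest of the three, below compound 2 by a 2.3-fold lower number from compound 2 to compound 3 (0.37 log units; beyond the scatter) and below compound 1 by a 16-fold lower number from compound 1 to compound 3 (1.21 log units; beyond the scatter). Compound 4, `CC(C)c1ccc(-c2csc(NC(=O)[C@H](CCCCNS(N)(=O)=O)NC(=O)OCc3ccccc3)n2)cc1`, differs from compound 3 by isopropyl in place of chloro on an aromatic carbon. For the measured compounds named here, no measured step changes a substituent on that ring; the steps seen so far, a 7.1-fold lower number from compound 1 to compound 2 (0.85 log units; beyond the scatter) and a 16-fold lower number from compound 1 to compound 3 (1.21 log units; beyond the scatter), concern what sits on the core, not what sits on the 4-chlorophenyl group. Compound 4 is therefore expected to give a step of no change at the digits printed from compound 3 to compound 4 (within the scatter), one not beyond the scatter. For compound 4 the estimate in this assay is 250 nM, within 100 nM to 700 nM.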

Compound 4, half-maximal inhibitory concentration: 1400 nM
For compound 4 the middle estimate is 5.6-fold (0.75 log units) below the measured one; measured number above the stated range.
By their numbers in this assay, from the lowest: compound 3; then compound 2; then compound 4; then compound 1.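

In this assay the group on the phenyl ring does count: a 5.6-fold higher number from compound 3 to compound 4 (0.75 log units; beyond the scatter) shows that isopropyl in place of chloro, para to a large group, gives back part of the gain seen with the 4-chlorophenyl group. The 4-isopropylphenyl group still beats hydrogen, with a 2.9-fold lower number from compound 1 to compound 4 (0.47 log units; beyond the scatter) marking that gain, but it trails ethoxycarbonyl, with a 2.4-fold higher number from compound 2 to compound 4 (0.38 log units; beyond the scatter) marking that loss. A phenyl ring on the core therefore does not set the number by itself. Nothing available explains the difference between chloro and isopropyl. Going by these compounds, how a methoxy group or an amine at this place would read remains open.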